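The source may hold more compounds than are shown below. What is called first, only, known or untested is meant among the compounds shown, and "the series" means these compounds.

Measured so far, in a functional assay for inhibition, with Homo sapiens as the target; a higher number here means a weaker inhibitor, a lower number a stronger inhibitor:

- Compound 1, `COc1cccc(Nc2nccc(-c3cccnc3)n2)c1`: compound 1 gives 300 nM.
- Compound 2, `c1cc(Nc2nccc(-c3cccnc3)n2)cc(OCCn2ccnc2)c1`: compound 2 gives 100 nM.
- Compound 3, `COc1cccc(Nc2nccc(-c3ccco3)n2)c1`: compound 3 gives 400 nM.

Compound 1 and compound 2 share a core and differ in one place: (1H-imidazol-1-yl)methyl in place of hydrogen on a saturated chain carbon bound to an oxygen on an aromatic ring. That change made a step of a 3.0-fold lower number from compound 1 to compound 2 (0.48 log units; beyond the scatter), a modest gain in potency that lies beyond the usual scatter of this kind of measurement.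

Compound 3 differs from compound 1 in the core itself: furan-2-yl in place of pyridin-3-yl on an aromatic carbon. The step here was a 1.3-fold higher number from compound 1 to compound 3 (0.12 log units; within the scatter), which is within the scatter, so the two cores cannot be told apart on these numbers alone.

Compound 4, `c1cc(Nc2nccc(-c3ccco3)n2)cc(OCCn2ccnc2)c1`, has not yet been measured. It carries the core of compound 3 and differs from compound 3 in one place: (1H-imidazol-1-yl)methyl in place of hydrogen on a saturated chain carbon bound to an oxygen on an aromatic ring. The place is described in the same words as for the change from compound 1 to compound 2, so this is the same change, now made on the other core.

Among the compounds with values here, with only one earlier example of this change, the expectation rests on that single step. Compound 4 is expected to show a step of a 2.7-fold lower number from compound 3 to compound 4 (0.43 log units; beyond the scatter), estimated from the step of a 3.0-fold lower number from compound 1 to compound 2 (0.48 log units; beyond the scatter) on the closely related core. Compound 4 is therefore estimated at 150 nM, with a range from 60 nM to 400 nM.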

Compound 4, half-maximal inhibitory concentration: 200 nM
Compound 4: the middle estimate sits 1.3-fold (0.12 log units) below what was measured, and the stated range covers the measured number.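

In this assay, replacing methoxy with 2-(1H-imidazol-1-yl)ethoxy on the furan-2-yl core gives a step of a 2.0-fold lower number from compound 3 to compound 4 (0.30 log units; within the scatter), and taken alone this step does not clearly separate the two compounds, yet it agrees with the same change on the pyridin-3-yl core: the same change on two cores in this assay, a 3.0-fold lower number (0.48 log units; beyond the scatter) from compound 1 to compound 2 and a 2.0-fold lower number (0.30 log units; within the scatter) from compound 3 to compound 4, 1.5-fold (0.18 log units) apart, within the scatter of two such steps. Putting furan-2-yl in place of pyridin-3-yl among the compounds that carry the imidazole chain gives a step of a 2.0-fold higher number from compound 2 to compound 4 (0.30 log units; within the scatter), and this swap also behaves alike in both settings: the same change on two cores in this assay, a 1.3-fold higher number (0.12 log units; within the scatter) from compound 1 to compound 3 and a 2.0-fold higher number (0.30 log units; within the scatter) from compound 2 to compound 4, 1.5-fold (0.18 log units) apart, within the scatter of two such steps. Within this small set, the change therefore carries from one core to the other with no detectable difference, but that rests on only two pairs of compounds, and it does not establish a real gain on the furan-2-yl core or rule out a difference smaller than the scatter.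

On these data alone, it remains open whether a longer chain carrying the imidazole ring, or an amine such as morpholine in place of that ring, would carry across the two cores in the same way. As far as these compounds go, it is also open whether the agreement would hold on a core with a third group, such as phenyl, in place of furan-2-yl or pyridin-3-yl.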